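The source may report more compounds than this note shows. Statements on the series, on what has been measured and on what is new or still open speak of the compounds shown alone.

Measured compounds:
- compound 1, `O=C(OCCc1ccc(Cl)c(Cl)c1)N(c1ccccc1)C1CN2CCC1CC2`, in an assay on CHO cells for displacement of a labelled ligand from muscarinic acetylcholine receptor M5 (Homo sapiens), read by scintillation counting, with a stated time of 2 h (on this read-out lower numbers stand for stronger inhibition and higher numbers for weaker inhibition), compound 1 gives 80 nM
- compound 2, `O=C(OCCc1ccccc1)N(c1ccccc1)C1CN2CCC1CC2`, in this assay compound 2 gives 260 nM
- compound 3, `O=C(OCCCc1ccccc1)N(c1ccccc1)C1CN2CCC1CC2`, in this assay compound 3 gives 260 nM

All three share one core and differ only in the group carried on the chain beyond the carbonyl. Compound 2 and compound 3 are separated by benzyl in place of phenyl on a saturated chain carbon, two bonds along the chain from an oxygen next to a carbonyl group, and in this assay this gives no change at the digits printed from compound 2 to compound 3 (within the scatter). Compound 1 stands apart from compound 2 by 3,4-dichlorophenyl in place of phenyl on a saturated chain carbon, two bonds along the chain from an oxygen next to a carbonyl group, and this change produced a 3.3-fold lower number from compound 2 to compound 1 (0.51 log units; beyond the scatter). Seen from compound 1, the move to compound 3 reads as a 3.3-fold higher number from compound 1 to compound 3 (0.51 log units; beyond the scatter).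

Compound 4, `O=C(OCCCc1ccc(Cl)c(Cl)c1)N(c1ccccc1)C1CN2CCC1CC2`, has not yet been measured in this assay. It differs from compound 3 by 3,4-dichlorophenyl in place of phenyl on a saturated chain carbon, three bonds along the chain from an oxygen next to a carbonyl group. Among the measured compounds shown here, this is the same kind of change as the one from compound 2 to compound 1, but not the same: there the new group sits two bonds along the chain from the oxygen, here it sits three bonds along the chain from the oxygen, so the cores of the two pairs are not identical.

Since the one occurrence of this kind of change gave a 3.3-fold lower number from compound 2 to compound 1 (0.51 log units; beyond the scatter), compound 4 is expected to show a step of about a 2.9-fold lower number from compound 3 to compound 4 (0.46 log units; beyond the scatter) from compound 3. That expectation rests on a single earlier pair, so its width is kept generous. Compound 4 is therefore estimated at 90 nM, between 35 nM and 250 nM.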

Compound 4, inhibition constant: 130 nM
Estimate against measurement, compound 4: 1.4-fold (0.16 log units) below; the range from low to high includes it.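

Carried to the core of compound 3, the swap of phenyl for 3,4-dichlorophenyl gives a 2.0-fold lower number from compound 3 to compound 4 (0.30 log units; within the scatter) in this assay, and the two occurrences of this change cannot be told apart: the same change on two cores in this assay, a 3.3-fold lower number (0.51 log units; beyond the scatter) from compound 2 to compound 1 and a 2.0-fold lower number (0.30 log units; within the scatter) from compound 3 to compound 4, 1.6-fold (0.21 log units) apart, within the scatter of two such steps This fits a step that carries over between these two cores, but it rests on only two pairs, and the step on the core of compound 3 lies within the scatter when read alone, so it does not establish a real change on that core or show that the size of the step is the same on both. The other two new steps, a 2.0-fold lower number from compound 2 to compound 4 (0.30 log units; within the scatter) and a 1.6-fold higher number from compound 1 to compound 4 (0.21 log units; within the scatter), also lie within the scatter, so compound 4 cannot be ranked against compound 1, compound 2 or compound 3 on these numbers.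

The compounds shown leave open whether a single chlorine, a methoxy group or a trifluoromethyl group on the ring would behave as 3,4-dichlorophenyl does, and whether the step would persist on a longer chain. They also leave open how the change would read if a pyridine ring replaced the unchanged phenyl group of the shared core.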